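This account rests on a few compounds, and the source may have more. Where it says the series, first, only, none or still open, it means among the compounds named here.

Measured compounds in an assay on isolated protein for inhibition of Calpain-1 catalytic subunit (Homo sapiens); on this read-out lower numbers stand for stronger inhibition and higher numbers for weaker inhibition:
Compound 1 `NC(=O)c1cn(-c2ccc(O)cc2F)c2cc(-c3ccncc3)ccc2c1=O`: 7000 nM
Compound 2 `NC(=O)c1cn(-c2ccc(O)cc2C(F)(F)F)c2cc(-c3ccncc3)ccc2c1=O`: 20000 nM
Compound 3 `NC(=O)c1cn(-c2ccc(O)cc2Cl)c2cc(-c3ccoc3)ccc2c1=O`: 2000 nM

Among these three, compound 3 has the lowest number in this assay, and the gaps to the other two are beyond the scatter; compound 1 sits nearest, compound 2 furthest. Compound 4 `NC(=O)c1cn(-c2ccc(O)cc2Cl)c2cc(-c3ccnc(F)c3)ccc2c1=O` has not yet been measured. It differs from compound 3 in one place: 2-fluoropyridin-4-yl in place of furan-3-yl on an aromatic carbon, sitting on an aromatic carbon of a six-membered aromatic ring of carbon only, part of a fused or bridged system of two rings.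

Going by the values given here, only one single-change step has been measured, a 2.9-fold higher number from compound 1 to compound 2 (0.46 log units; beyond the scatter), and it concerns a different position, the group on the phenol-bearing ring, so it says nothing direct about the change to compound 4. Compound 1 carries a pyridin-4-yl where compound 3 carries furan-3-yl, but it also carries fluoro instead of chloro, so its higher number cannot be attributed to either change alone. Among the compounds with values here, with no step bearing on this position, the expectation for compound 4 is a number close to that of compound 3, a 1.3-fold higher number from compound 3 to compound 4 (0.10 log units; within the scatter), with wide uncertainty. Compound 4 is therefore estimated at 2500 nM, within a range from 700 nM to 9000 nM.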

Compound 4, half-maximal inhibitory concentration: 30000 nM
Compound 4: the middle estimate sits 12-fold (1.08 log units) below what was measured; measured number outside the range, above it.
By their numbers in this assay, from the lowest: compound 3; then compound 1; then compounds 2 and 4 (each within the scatter of the next).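

In this assay, the swap at this position gives a 15-fold higher number from compound 3 to compound 4 (1.18 log units; beyond the scatter) and so marks the position on the six-membered aromatic ring of carbon only as one where the choice of group matters greatly. Going by these compounds alone, this is the first single-change step measured here, and it shows that 2-fluoropyridin-4-yl cannot stand in for furan-3-yl without a large loss of inhibition, even though each group counts one hydrogen-bond acceptor and no net charge. No measurement available here accounts for this loss.

The change alters the ring size, the hetero atom and the presence of fluorine all at once, so these two compounds cannot show which of those differences matters, and pyridin-4-yl paired with the chloro of compound 3 would be needed to begin separating them. Going by these compounds, whether a thiophene ring or a pyridine carrying an amine at this position would stay close to compound 3 or fall away like compound 4 also remains open.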